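A few compounds are considered here, and "the series" means these few. Any claim that something is new, unique, unknown or untested is made for them only; others in the source may bear on it.

Of the compounds shown here, three have so far been measured in a physicochemical assay for lipophilicity, at pH 7.4; on this read-out higher numbers stand for higher lipophilicity and lower numbers for lower lipophilicity. Compound 1 `CCc1ccc(N(CC(C)C)S(=O)(=O)c2ccc3c(c2)C(O)C[C@H](C2CCOCC2)O3)cc1` gives 4.12. Compound 2 `CC(C)CN(c1ccc(C#N)cc1)S(=O)(=O)c1ccc2c(c1)C(O)CC(C1CCOCC1)O2` gives 3.07, which is the lowest of the three numbers, and compound 3 `CCc1ccc(N(CC(C)C)S(=O)(=O)c2ccc3c(c2)C(N)CC(C2CCOCC2)O3)cc1` gives 3.08. The number for compound 3 lies within the usual scatter of that for compound 2, whereas the number for compound 1 lies beyond it. Compound 4 `CC(C)CN(c1ccc(F)cc1F)S(=O)(=O)c1ccc2c(c1)C(O)CC(C1CCOCC1)O2` has not yet been measured. It differs from compound 2 in a single place: 2,4-difluorophenyl in place of 4-cyanophenyl on a sulfonamide nitrogen. Among the measured compounds shown here, no measured pair differs by this change alone, so the outlook rests on the numbers above. A rise beyond the scatter is expected in this assay, the expected step being a number 0.83 log units higher from compound 2 to compound 4 (beyond the scatter). Compound 4 is therefore estimated at 3.9, in a range from 3.5 to 4.3.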

Compound 4, distribution coefficient: 3.53
Compound 4: middle estimate off by 0.37 log units, on the high side; the measured number falls inside the stated range.
By their numbers in this assay, from the lowest: compounds 2 and 3 (each within the scatter of the next); then compound 4; then compound 1.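

In this assay, the swap of 4-cyanophenyl for 2,4-difluorophenyl on a sulfonamide nitrogen gives a number 0.46 log units higher from compound 2 to compound 4 (beyond the scatter), the first step read at this position, and it shows that the number moves with this group, if only modestly. Both groups have a six-membered aromatic ring of carbon only and no net charge, so the step comes with a change in what that ring carries. Nothing at hand gives a cause for this step.

Open, going by these compounds, is whether either fluorine alone would give the same step. Also open, on these data alone, is what a methoxy group or a carboxylic acid on that phenyl ring would give.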